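Difluorophenyl in Place of Dimethoxyphenyl on the Amine Nitrogen

The source may hold more compounds than are shown below. What is called first, only, known or untested is meant among the compounds shown, and "the series" means these compounds.

In an ADME assay on HEK293 cells (Homo sapiens) for cytotoxicity, read by MTT assay, with a stated time of 48 h (on this read-out higher numbers stand for weaker inhibition and lower numbers for stronger inhibition), compound 1 `Cc1ccc(S(=O)(=O)/N=C(/CCNC2=CC(=O)c3ccccc3C2=O)Nc2ccc(F)cc2)cc1` gives 55100 nM, compound 2 `Cc1ccc(S(=O)(=O)/N=C(/CCNC2=CC(=O)c3ccccc3C2=O)Nc2cccc(C(F)(F)F)c2)cc1` gives 91500 nM, and compound 3 `COc1ccc(N/C(CCNC2=CC(=O)c3ccccc3C2=O)=N\S(=O)(=O)c2ccc(C)cc2)cc1OC` gives 60600 nM, the second highest of the three numbers, with both neighbours within the scatter of it. The steps of a 1.7-fold higher number from compound 1 to compound 2 (0.22 log units; within the scatter), a 1.1-fold higher number from compound 1 to compound 3 (0.04 log units; within the scatter) and a 1.5-fold lower number from compound 2 to compound 3 (0.18 log units; within the scatter) all stay inside the scatter, so exchanging the aryl group on the amine nitrogen has not so far shifted this assay. Compound 4 `Cc1ccc(S(=O)(=O)/N=C(/CCNC2=CC(=O)c3ccccc3C2=O)Nc2ccc(F)c(F)c2)cc1` differs from compound 3 in one place: 3,4-difluorophenyl in place of 3,4-dimethoxyphenyl on an amine nitrogen. The step of a 1.1-fold higher number from compound 1 to compound 3 (0.04 log units; within the scatter) already exchanged a fluorinated ring for the dimethoxy ring with no change beyond the scatter, so no step beyond the scatter is expected here either, a 1.0-fold higher number from compound 3 to compound 4 (0.01 log units; within the scatter). Compound 4 is therefore estimated at 62000 nM, with a range from 30000 nM to 125000 nM.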

Compound 4, half-maximal inhibitory concentration: 55200 nM
Compound 4: middle estimate off by 1.1-fold (0.05 log units), on the high side, and the stated range covers the measured number.
By their numbers in this assay, from the lowest: compounds 1, 4, 3 and 2 (each within the scatter of the next).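

Fluoro in place of hydrogen on the aromatic ring of compound 1 leaves the read-out in this assay unmoved, a 1.0-fold higher number from compound 1 to compound 4 (0.00 log units; within the scatter). Replacing 3,4-dimethoxyphenyl, with its 2 hydrogen-bond acceptors, by 3,4-difluorophenyl, with none, also stays inside the scatter, a 1.1-fold lower number from compound 3 to compound 4 (0.04 log units; within the scatter), as does the exchange for 3-(trifluoromethyl)phenyl, a 1.7-fold lower number from compound 2 to compound 4 (0.22 log units; within the scatter). No evidence is available to explain this insensitivity. The compounds shown leave open whether a carboxylic acid or an amine on this ring would move the number beyond the scatter. They also leave open whether a cyclohexyl group in place of the aromatic ring would do so.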